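A few compounds are considered here, and "the series" means these few. Any claim that something is new, unique, unknown or untested is made for them only; others in the source may bear on it.

Of the compounds shown here, three built on one shared core have been measured in a functional assay, read by spectrophotometry, with a stated time of 30 min, tested at 100 ug/mL; a higher number here means a stronger effect of the compound at the concentration tested, a lower number a weaker effect. Compound 1 `CN1CCN(CC(=O)Nc2nc3ccccc3[nH]2)CC1` gives 45%, compound 2 `O=C(CN1CCN(c2ccccc2)CC1)Nc1nc2ccccc2[nH]1` gives 32.2%, and compound 3 `COc1ccc(N2CCN(CC(=O)Nc3nc4ccccc4[nH]3)CC2)cc1` gives 38.9%. Compound 3 thus stands second highest of the three, within the scatter of both compound 1 and compound 2. Compound 4 `COc1ccccc1N1CCN(CC(=O)Nc2nc3ccccc3[nH]2)CC1` differs from compound 3 by 2-methoxyphenyl in place of 4-methoxyphenyl on an amine nitrogen in a ring. The measured steps that touch this part of the molecule are a number 12.8 percentage points lower from compound 1 to compound 2 (beyond the scatter), a number 6.1 percentage points lower from compound 1 to compound 3 (within the scatter) and a number 6.7 percentage points higher from compound 2 to compound 3 (within the scatter); none of them tests a change of this kind, and two lie within the scatter. No step beyond the scatter is therefore expected for compound 4, with an estimated change of a number 1.9 percentage points lower from compound 3 to compound 4 (within the scatter). Compound 4 is expected to give about 37%, between 25% and 50%.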

Compound 4, a percentage reported as activity, at one concentration (the size of the read-out at that concentration, not a potency): 43.2%
Compound 4: middle estimate off by 6.2 percentage points, on the low side, and the stated range covers the measured number.
By their numbers in this assay, from the lowest: compounds 2, 3, 4 and 1 (each within the scatter of the next, the first and the last beyond it).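

Exchanging 4-methoxyphenyl for 2-methoxyphenyl on this ring nitrogen gives a number 4.3 percentage points higher from compound 3 to compound 4 (within the scatter), so this assay does not separate these two placements of the methoxy group. The 2-methoxyphenyl group does, however, give a methoxy step beyond the scatter, a number 11 percentage points higher from compound 2 to compound 4 (beyond the scatter), and it stays level with methyl, a number 1.8 percentage points lower from compound 1 to compound 4 (within the scatter). Nothing available explains these numbers. Still open, as far as these compounds go, is how a benzyl or acetyl group on this ring nitrogen would compare, and whether hydroxy in place of methoxy on the 2-methoxyphenyl ring would keep the number.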